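Replacing ethyl with pyridin-2-yl on a ring amine nitrogen

The source may report more compounds than this note shows. Statements on the series, on what has been measured and on what is new or still open speak of the compounds shown alone.

Of the compounds shown here, three on a shared core have been measured so far. In a functional assay on A549 cells (Homo sapiens) for antiproliferative activity, read by sulforhodamine B assay, with a stated time of 48 h (a higher number here means a weaker inhibitor, a lower number a stronger inhibitor), compound 1 (`COc1ccc(C[C@@H](O)/C=C/C=C/C(=O)N2CCN(C)CC2)cc1OC`) stands at 22200 nM and compound 2 (`COc1ccc(C[C@@H](O)/C=C/C=C/C(=O)N2CCN(c3ccccc3)CC2)cc1OC`) at 14200 nM while compound 3 (`CCN1CCN(C(=O)/C=C/C=C/[C@H](O)Cc2ccc(OC)c(OC)c2)CC1`) stands at 15700 nM on the same scale. Compound 3 lies within the scatter of both other compounds (a 1.4-fold lower number from compound 1 to compound 3 (0.15 log units; within the scatter); a 1.1-fold higher number from compound 2 to compound 3 (0.04 log units; within the scatter)), so the three form no order.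

Compound 4 (`COc1ccc(C[C@@H](O)/C=C/C=C/C(=O)N2CCN(c3ccccn3)CC2)cc1OC`) carries pyridin-2-yl in place of ethyl on an amine nitrogen in a ring. Two measured changes at that nitrogen bear on it: phenyl in place of methyl (a 1.6-fold lower number from compound 1 to compound 2 (0.19 log units; within the scatter)) and ethyl in place of phenyl (a 1.1-fold higher number from compound 2 to compound 3 (0.04 log units; within the scatter)). Both stayed within the scatter, even though the second swaps a small chain for an aromatic ring, the same kind of exchange that compound 4 makes. For the measured compounds named here, no measured compound carries pyridin-2-yl itself, so that group remains untested. No step beyond the scatter is therefore expected in this assay for this change, and the expected step is small (a 1.1-fold lower number from compound 3 to compound 4 (0.05 log units; within the scatter)). Compound 4 is estimated at 14000 nM (expected range 7000 nM to 28000 nM).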

Compound 4, half-maximal inhibitory concentration: 8130 nM
Beside the measured number, compound 4's estimate is 1.7-fold (0.24 log units) above it, and the stated range covers the measured number.
By their numbers in this assay, from the lowest: compounds 4, 2, 3 and 1 (each within the scatter of the next, the first and the last beyond it).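

In this assay, for the compounds shown here, pyridin-2-yl gives the first step at this amine nitrogen in a ring to pass the scatter, a modest one (a 2.7-fold lower number from compound 1 to compound 4 (0.44 log units; beyond the scatter)), whereas the earlier exchanges at this nitrogen all stayed within it. That separation holds only against methyl: the step from ethyl (a 1.9-fold lower number from compound 3 to compound 4 (0.29 log units; within the scatter)) and the step from phenyl (a 1.7-fold lower number from compound 2 to compound 4 (0.24 log units; within the scatter)) both remain within the scatter, so pyridin-2-yl cannot be told apart from either group, and ethyl and phenyl are themselves not separated from methyl. No supporting measurement bears on the origin of the step from methyl.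

Going by these compounds, it remains open whether the ring nitrogen of pyridin-2-yl contributes anything beyond the aromatic ring itself, a question that pyridin-3-yl, pyridin-4-yl or pyrimidin-2-yl on the same amine nitrogen could help to settle. On these data alone, it is also open whether a non-aromatic ring such as cyclohexyl, or an acetyl group, at this nitrogen would stand with methyl or with pyridin-2-yl, and whether the modest step would recur with a different group on the shared core.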